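A few compounds are considered here, and "the series" means these few. Any claim that something is new, unique, unknown or untested is made for them only; others in the source may bear on it.

Compound 1 `CSc1ccc(C2=C(c3ccc(C)c(C)c3)C(=O)N3CCCC3C2)cc1`: 300 nM
Compound 2 `COc1ccc(C2=C(c3ccc(SC)cc3)CC3CCCN3C2=O)cc1OC`: 8000 nM

Among the compounds with values here, in a functional assay on A498 cells (Homo sapiens) for cytotoxicity (on this read-out higher numbers stand for weaker inhibition of growth and lower numbers for stronger inhibition of growth), compound 1 gives 300 nM, the lowest of the numbers so far, well clear of compound 2 at 8000 nM. Compound 3 `CSc1ccc(C2=C(c3ccc(Br)cc3)C(=O)N3CCCC3C2)cc1` keeps the core of compound 1 and its 4-(methylsulfanyl)phenyl group, but carries 4-bromophenyl in place of 3,4-dimethylphenyl on a double-bonded ring carbon. Within the data shown here, no measured pair shows this change alone, so the expectation rests on little. In this assay the expected step is a 1.3-fold higher number from compound 1 to compound 3 (0.12 log units; within the scatter), a modest one toward a higher number that may stay within the scatter. For compound 3 the estimated value is 400 nM, with an expected range from 120 nM to 1500 nM.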

Compound 3, concentration for 50% growth inhibition: 7000 nM
Beside the measured number, compound 3's estimate is 18-fold (1.24 log units) below it; measured number outside the range, above it.
By their numbers in this assay, from the lowest: compound 1; then compounds 3 and 2 (each within the scatter of the next).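

With the core and the 4-(methylsulfanyl)phenyl group held fixed, 4-bromophenyl in place of 3,4-dimethylphenyl on a double-bonded ring carbon gives a 23-fold higher number from compound 1 to compound 3 (1.37 log units; beyond the scatter) in this assay. Growth inhibition in these cells therefore depends strongly on which phenyl group stands at this position, something the earlier compounds, which differ in more than one place, could not show. Nothing measured here accounts for the size of this step. The compounds shown leave open whether the loss of the two methyl groups or the arrival of the bromine matters more, since neither 4-methylphenyl nor 4-chlorophenyl stands among them. As far as these compounds go, it also remains open how a phenyl group bearing an amine would fare here.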